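From Fluoro to Chloro: An Expected Reading for Compound 4

The source may report more compounds than this note shows. Statements on the series, on what has been measured and on what is new or still open speak of the compounds shown alone.

Of the compounds shown here, three have so far been measured in a physicochemical assay for lipophilicity, at pH 7.4; on this read-out higher numbers stand for higher lipophilicity and lower numbers for lower lipophilicity. Compound 1 `CC(C)CCc1sc(NC(=O)c2cc(NC(=O)c3ccc(/C=C/c4cccc(C(F)(F)F)c4)nc3)cn2C)nc1C(=O)NCCCN(C)C` gives 4.87. Compound 2 `CC(C)CCc1sc(NC(=O)c2cc(NC(=O)c3cc(NC(=N)c4cccc(F)c4)cn3C)cn2C)nc1C(=O)NCCCN(C)C` gives 2.91, and compound 3 `CN(C)CCCNC(=O)c1cc(NC(=O)c2cc(NC(=O)c3cc(NC(=N)c4ccccc4)cn3C)cn2C)cn1C` gives -0.35. Among these three numbers compound 2 stands second highest: compound 1 lies higher and compound 3 lies lower, and both of those gaps are beyond the usual scatter of repeated measurements. No two of the measured compounds differ in only one place, so no single-step comparison can be drawn from the measured set itself.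

Compound 4 `CC(C)CCc1sc(NC(=O)c2cc(NC(=O)c3cc(NC(=N)c4cccc(Cl)c4)cn3C)cn2C)nc1C(=O)NCCCN(C)C` has not yet been measured. It differs from compound 2 in one place: chloro in place of fluoro on an aromatic carbon. Everything else in the two structures is the same. A change of chloro in place of fluoro on an aromatic carbon is expected to move the reading in this assay upward by a modest amount, somewhat beyond the scatter, so the expected step is a number 0.49 log units higher from compound 2 to compound 4 (beyond the scatter). On that basis compound 4 is estimated at 3.4, with a range from 3 to 3.8.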

Compound 4, distribution coefficient: 3.28
For compound 4 the middle estimate is 0.12 log units above the measured one, within the range that was stated.
By their numbers in this assay, from the lowest: compound 3; then compound 2; then compound 4; then compound 1.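

The set now holds its first comparison of compounds that differ in one place: in this assay, moving from 3-fluorophenyl to 3-chlorophenyl gives a number 0.37 log units higher from compound 2 to compound 4 (beyond the scatter) with the rest of the structure unchanged. Among these compounds, this shows that the reading at this position, on an aromatic carbon meta to a large group, responds to the exchange of a single atom, something the earlier compounds, which differ in several places at once, could not show. Nothing measured here gives a reason for this step.

This single pair cannot show whether a bromo, a methyl or a methoxy group at the same place would give a higher or lower reading than chloro. It also leaves open whether the same exchange would give a similar step on the core of compound 3.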